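A Chain Replaces a Ring on the Shared Core

The compounds below may be only part of what the source reports. "The series", "measured", "known", "first", "only" and "open" are said of these compounds alone.

- Compound 1 `Nc1cccc(Nc2c(C(=O)NCc3ccc(F)cc3)nc(Br)c3cccnc23)c1` gives 8000 nM as its value
- Compound 2 `N[C@H]1CC[C@H](Nc2c(C(=O)NCc3ccco3)nc(Br)c3cccnc23)CC1` gives > 10000 nM as a limit of the assay, not a number

Among the compounds with values here, in a functional assay on MDA-MB-435 cells (Homo sapiens) for cytotoxicity, read by MTT assay, with a stated time of 72 h (on this read-out higher numbers stand for weaker inhibition and lower numbers for stronger inhibition), compound 1 holds the only actual number so far, and the other result is a limit. Compound 3 `NCCCNc1c(C(=O)NCc2ccc(F)cc2)nc(Br)c2cccnc12` keeps the core of compound 1 and changes one place (3-aminopropyl in place of 3-aminophenyl on a nitrogen on an aromatic ring), with 3-aminopropyl in place of 3-aminophenyl on a nitrogen on an aromatic ring. Within the data shown here, no measured pair of close neighbours shows what such a change does, so no step beyond the scatter is expected in this assay for now. The a 1.6-fold lower number from compound 1 to compound 3 (0.20 log units; within the scatter) is expected to stay within that scatter. For compound 3 the estimated value is 5000 nM with an expected range from 1500 nM to 10000 nM on repeated measurement.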

Compound 3, half-maximal inhibitory concentration: 5000 nM
Compound 3: the middle estimate sits on the measured number at the digits printed; the range from low to high includes it.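

In this assay, putting 3-aminopropyl in place of 3-aminophenyl on a nitrogen on an aromatic ring gives a 1.6-fold lower number from compound 1 to compound 3 (0.20 log units; within the scatter). Within the data shown here, this is the first readable step at this position, and it shows that an open chain can stand in for the ring here without a step beyond the scatter. Compound 2 is a limit of the assay and not a number, and it differs from compound 1 in more than one place: the limit of > 10000 nM in this assay, at which 1 of the 3 values shown sits. Open at this nitrogen is what a longer chain ending in an amine, or a chain ending in a carboxylic acid, would give.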